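A few compounds are considered here, and "the series" means these few. Any claim that something is new, unique, unknown or untested is made for them only; others in the source may bear on it.

Measured so far in an ADME assay (liver) for metabolic stability, with Liver microsome (Homo sapiens) as the target, read by LC-MS, using microsomes, tested at 1 uM; a lower number here means slower removal, a higher number faster removal of the compound:
compound 1 `CNc1nc(NCCCN(C)C)c2sc(-c3ccc(-n4cccn4)cc3)cc2n1`: 18.4 uL/min
compound 2 `CNc1nc(NCCCN(C)C)c2sc(-c3ccc(C(F)(F)F)cc3)cc2n1`: 14 uL/min
compound 3 `CNc1nc(NCCCN(C)C)c2sc(-c3ccc(N4CCNCC4)cc3)cc2n1`: 36 uL/min

Compound 2 stands at 14 uL/min in this assay; compound 1 lies within the scatter of it a 1.3-fold lower number from compound 1 to compound 2 (0.12 log units; within the scatter), while compound 3 lies beyond it a 2.6-fold higher number from compound 2 to compound 3 (0.41 log units; beyond the scatter). Compound 4 `CNc1nc(NCCCN(C)C)c2sc(-c3ccc(C(F)(F)F)cc3Cl)cc2n1` differs from compound 2 by one change: chloro in place of hydrogen on an aromatic carbon. Within the data shown here, every measured step here swaps the group at the far end of the six-membered aromatic ring of carbon only; none adds a chloro while keeping the trifluoromethyl, so no measured step bears directly on this change. With nothing pointing either way, a step within the scatter is expected a 1.1-fold higher number from compound 2 to compound 4 (0.03 log units; within the scatter). Compound 4 is therefore estimated at 15 uL/min, most likely between 7 uL/min and 32 uL/min.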

Compound 4, intrinsic clearance in a liver preparation (reported as CLH), per the amount of preparation that the assay uses in the Liver microsome assay: 13 uL/min
Estimate against measurement, compound 4: 1.2-fold (0.06 log units) above, and the stated range covers the measured number.
By their numbers in the Liver microsome assay, from the lowest: compounds 4, 2, 1 and 3 (each within the scatter of the next, the first and the last beyond it).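

Chloro on an aromatic carbon, ortho to a large group and meta to a trifluoromethyl group, leaves removal unchanged in the Liver microsome assay (a 1.1-fold lower number from compound 2 to compound 4 (0.03 log units; within the scatter)). In a physicochemical assay for lipophilicity, read by HPLC, at pH 7.4 (a lower number here means a more polar compound, a higher number a more lipophilic compound), compound 2 gives 4.1 and compound 4 gives 4.5, a gap beyond the scatter. This chloro therefore makes the compound more lipophilic without faster removal: (the measured distribution coefficient of compound 2, 4.1, and of compound 4, 4.5, a number 0.40 log units higher (beyond the scatter)).

The compounds shown leave open whether fluoro or methoxy at this place would behave alike. They also leave open whether chloro would do the same with piperazin-1-yl in place of trifluoromethyl.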